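The compounds below may be only part of what the source reports. "The series", "measured", "known", "first", "only" and "open" are said of these compounds alone.

Series notes. The shared core of compound 1 `O=C1COc2ccc(-c3cccc(NS(=O)(=O)c4ccc(F)cc4)c3)cc2N1C1CC1` carries cyclopropyl on the amide-type nitrogen in the ring. In a functional assay on HepG2 cells (Homo sapiens) for antiproliferative activity, read by MTT assay, with a stated time of 72 h (on this read-out higher numbers stand for weaker inhibition and lower numbers for stronger inhibition), compound 1 gives only a limit, > 40000 nM, and no number. Compound 2 `O=C1COc2ccc(-c3cccc(NS(=O)(=O)c4ccc(F)cc4)c3)cc2N1c1ccc(Cl)cc1` carries 4-chlorophenyl in place of cyclopropyl, and in this assay compound 2 gives 27800 nM. The step of an at least 1.4-fold lower number from compound 1 to compound 2 (0.15 log units; that floor lies within the scatter) rests on the limit of > 40000 nM in this assay, at which 1 of the 2 values shown sits, and so cannot be sized beyond its floor. Within the data shown here, compound 2 thus stands as the only number in this assay; the one other value is a limit.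

Compound 3 `O=C1COc2ccc(-c3cccc(NS(=O)(=O)c4ccc(F)cc4)c3)cc2N1c1ccc(F)cc1` differs from compound 2 by fluoro in place of chloro on an aromatic carbon. Among the measured compounds shown here, no measured step exchanges one halogen for another on that ring; the single step in hand alters the group on the amide-type nitrogen itself and gives no guide to fluoro in place of chloro. A step of a 1.3-fold higher number from compound 2 to compound 3 (0.10 log units; within the scatter) within the scatter is therefore expected, in no set direction. Compound 3 is estimated at 35000 nM in this assay, with a range from 15000 nM to 80000 nM. A limit rather than a number for compound 3 remains quite possible.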

Compound 3, half-maximal inhibitory concentration: > 40000 nM
Compound 3 was reported as a limit (the forecaster's own chance of this, stated with the estimate: 40%); middle value at least 1.1-fold (0.05 log units) from the limit.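

Among these compounds, the change from 4-chlorophenyl to 4-fluorophenyl is the first in this set made on the aromatic ring rather than to the whole group on the amide-type nitrogen, and in this assay it gives an at least 1.4-fold higher number from compound 2 to compound 3 (0.15 log units; that floor lies within the scatter). That floor leaves chloro and fluoro unseparated at this place, and the step from cyclopropyl to 4-fluorophenyl, set between two limits, cannot be read. Among the compounds shown here, compound 2 remains the only compound with a number, and the other two compounds share a single limit of the read-out: the limit of > 40000 nM in this assay, at which 2 of the 3 values shown sit.

Going by these compounds, what a methoxy, an amine or a carboxylic acid in place of the halogen on this ring would give in this assay stays open, as does the result for an unsubstituted phenyl on the amide-type nitrogen. Also open, on these data alone, is whether a change elsewhere on the shared core, such as on the aromatic ring of the sulfonamide, would give numbers clearly apart from compound 2 and so allow the steps at this position to be sized.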